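The source may hold more compounds than are shown below. What is called first, only, known or untested is meant among the compounds shown, and "the series" means these compounds.

Measured in an ADME assay on L132 cells (Homo sapiens) for cytotoxicity, read by MTT assay, with a stated time of 72 h; on this read-out higher numbers stand for weaker inhibition and lower numbers for stronger inhibition:
Compound 1 `COc1ccc(C2=C(c3cc(OC)c(OC)c(OC)c3)C(=O)CC2O[SiH2]C(C)(C)C)cc1`: > 100 ug/mL, a limit.
Compound 2 `COC(=O)c1cc(C2=C(c3cc(OC)c(OC)c(OC)c3)C(=O)CC2O[SiH2]C(C)(C)C)ccc1OC`: > 100 ug/mL, a limit.
Compound 3 `COc1cc(C2=C(c3ccc(SC)cc3)CC(O[SiH2]C(C)(C)C)C2=O)cc(OC)c1OC`: < 1 ug/mL, a limit.

Compound 2 stands at the limit of > 100 ug/mL in this assay, at which 2 of the 3 values shown sit, so it gives no number to start from. Compound 3 alone sits at the limit of < 1 ug/mL in this assay, at which 1 of the 3 values shown sits. Compound 4 `COCOc1cc(C2=C(c3cc(OC)c(OC)c(OC)c3)C(=O)CC2O[SiH2]C(C)(C)C)ccc1OC` carries methoxymethoxy in place of methoxycarbonyl on an aromatic carbon, ortho to a methoxy group: methoxymethoxy in place of methoxycarbonyl on an aromatic carbon. For the measured compounds named here, the one measured step at this carbon is a step that the two limits leave unreadable from compound 1 to compound 2, so no size carries over. With compound 1 and compound 2 both at the limit of > 100 ug/mL in this assay, at which 2 of the 3 values shown sit, no step beyond the scatter is expected in this assay, and no direction can be read. The estimated change is a number no higher from compound 2 to compound 4 (the limit leaves the size open). For compound 4 the estimated value is 100 ug/mL, with an expected range of 30 ug/mL to 300 ug/mL.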

Compound 4, half-maximal inhibitory concentration: 32 ug/mL
Compound 4: the middle estimate sits 3.1-fold (0.49 log units) above what was measured; the measured number falls inside the stated range.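

In this assay, methoxymethoxy in place of methoxycarbonyl gives an at least 3.1-fold lower number from compound 2 to compound 4 (0.49 log units; beyond the scatter), and methoxymethoxy in place of hydrogen gives an at least 3.1-fold lower number from compound 1 to compound 4 (0.49 log units; beyond the scatter). From the compounds shown here alone, this aromatic carbon, ortho to a methoxy group, therefore does respond to the group it carries, although both steps start from a limit and their full size stays open. The earlier step at this carbon, hydrogen to methoxycarbonyl, cannot be read, since both its ends are limits: the limit of > 100 ug/mL in this assay, at which 2 of the 4 values shown sit.

Going by these compounds, whether the ether oxygen attached to the ring is enough on its own remains open. A hydroxy group, an amine or a longer alkoxy chain at this carbon would test that.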